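Swapping a piperidine for a benzyl-ethyl amine on the core

This account rests on a few compounds, and the source may have more. Where it says the series, first, only, none or still open, it means among the compounds named here.

Measured compounds:
- compound 1 `CN(C)CCN(CCN(C)C)c1ccc(C(=O)N2CCc3ccc(OS(N)(=O)=O)cc3C2)cc1`: 15.9%
- compound 2 `CCN(Cc1cccnc1)c1ccc(C(=O)N2CCc3ccc(OS(N)(=O)=O)cc3C2)cc1`: 85.2%
- compound 3 `NS(=O)(=O)Oc1ccc2c(c1)CN(C(=O)c1ccc(N3CCCCC3)cc1)CC2`: 38.3%

All three compounds share one core and differ only in the amine attached to an aromatic carbon. In an assay on HEK293 cells for inhibition of Steryl-sulfatase (Homo sapiens), tested at 1 uM (a lower number here means a weaker effect, a higher number a stronger effect of the compound at the concentration tested), compound 3 gives 38.3%, the second highest of the three numbers. Compound 1 sits lower, a number 22.4 percentage points higher from compound 1 to compound 3 (beyond the scatter), while compound 2 sits clearly higher, a number 46.9 percentage points lower from compound 2 to compound 3 (beyond the scatter).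

The step now considered leads to compound 4 `CCN(Cc1ccccc1)c1ccc(C(=O)N2CCc3ccc(OS(N)(=O)=O)cc3C2)cc1`, which has not yet been measured. Compared with compound 3 the change is benzyl(ethyl)amino in place of piperidin-1-yl on an aromatic carbon.

Going by the values given here, the step that bears most on this is the one between compound 2 and compound 3, since the group in compound 2, ethyl((pyridin-3-yl)methyl)amino, is closely related to the incoming benzyl(ethyl)amino group; the data gave a number 46.9 percentage points lower from compound 2 to compound 3 (beyond the scatter). Reversing a change of that kind, a large rise is expected here. Compound 4 is therefore expected to reach 80% in this assay, with a range from 55% to 95%, which means an expected step of a number 41.7 percentage points higher from compound 3 to compound 4 (beyond the scatter).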

Compound 4, a percentage reported as inhibition, at one concentration (the size of the read-out at that concentration, not a potency): 83.6%
Compound 4: middle estimate off by 3.6 percentage points, on the low side; the range from low to high includes it.
By their numbers in this assay, from the lowest: compound 1; then compound 3; then compounds 4 and 2 (each within the scatter of the next).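

In this assay the change to benzyl(ethyl)amino gives a number 45.3 percentage points higher from compound 3 to compound 4 (beyond the scatter) and so shows that this place, on an aromatic carbon para to a large group, responds strongly to the amine it carries, even though the leaving and entering groups each have no net charge and one hydrogen-bond acceptor. Replacing pyridin-3-yl with phenyl gives a number 1.6 percentage points lower from compound 2 to compound 4 (within the scatter) and leaves the number unchanged within the scatter, so the high value of compound 2 does not depend on the nitrogen of its pyridine ring. The bulky amine of compound 1 is now left further behind by a second high compound, with a number 67.7 percentage points higher from compound 1 to compound 4 (beyond the scatter) as the step, which means that two closely related groups reach the top of this small set while piperidin-1-yl and bis(2-(dimethylamino)ethyl)amino do not.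

No measurement shown gives a reason for these differences. Still open, as far as these compounds go, is whether the ethyl on the nitrogen matters, for instance whether a methyl or a propyl chain in its place, or a carboxylic acid or a fluorine on the phenyl ring, would keep the number this high.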